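This account rests on a few compounds, and the source may have more. Where it says the series, first, only, none or still open, it means among the compounds named here.

Working notes on the series. Among the measured compounds shown here, compound 1 `Cc1cc(O)c(C2=NN(c3ccc(S(N)(=O)=O)cc3)C(c3ccccc3)C2)cc1Cl` is one of two compounds measured in a functional assay on the whole organism (strain Wistar) for inhibition, with Rattus norvegicus as the target, read by paw edema, with stated times of 30 min and 5 h, at a dose of 20 mg/kg by the oral route; a higher number here means more inhibition at the dose given (going by the name of the read-out), a lower number less inhibition; compound 1 gives 60.3%. Compound 2 `COc1ccc(C2CC(c3cc(Cl)c(C)cc3O)=NN2c2ccc(S(N)(=O)=O)cc2)cc1OC` gives 68.3% in this assay. Compound 1 stands at the low end of the two numbers shown; the step of a number 8 percentage points higher from compound 1 to compound 2 (within the scatter), however, lies within the scatter, so no order between the two is claimed. That step alters only the group on a saturated ring carbon.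

Compound 3 `COc1cc(C)c(Cl)cc1C1=NN(c2ccc(S(N)(=O)=O)cc2)C(c2ccccc2)C1` is not yet measured in this assay. It differs from compound 1 in one place: methyl in place of hydrogen on an oxygen on an aromatic ring. For the measured compounds named here, no measured pair touches the hydroxy group on the aromatic ring; the only measured step, a number 8 percentage points higher from compound 1 to compound 2 (within the scatter), sits at another place and stays within the scatter, so it gives no guide for this change. The numbers shown offer nothing that points to a shift beyond the scatter in either direction. Compound 3 is expected to give 55% in this assay, with a range of 38% to 70%. The expected step of a number 5.3 percentage points lower from compound 1 to compound 3 (within the scatter) is thus estimated to stay within the scatter, with wide uncertainty for an untested change.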

Compound 3, a percentage reported as inhibition, in the whole organism at one dose (the size of the read-out at that dose, not a potency): 59.5%
Estimate against measurement, compound 3: 4.5 percentage points below; the measured number falls inside the stated range.
By their numbers in this assay, from the lowest: compounds 3, 1 and 2 (each within the scatter of the next).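

Hydroxy to methoxy on the 5-chloro-2-hydroxy-4-methylphenyl group gives a number 0.8 percentage points lower from compound 1 to compound 3 (within the scatter) in this assay, the first measured change at this position. With methyl on that oxygen, compound 3 gives 59.5%, so within this pair the hydrogen on the oxygen is not needed to keep a number of this size at the dose given. No measurement at hand accounts for this outcome.

As far as these compounds go, it remains open whether an ethyl or benzyl group on the same oxygen, or an amine in place of the hydroxy group, would also stay within the scatter, and whether the hydroxy to methoxy change would read the same with the 3,4-dimethoxyphenyl group of compound 2 on the saturated ring carbon. As the read-out gives the size of the inhibition at one dose, the pair also leaves open whether compound 1 and compound 3 would stay this close at other doses, or at times other than those stated.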